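Swapping the aryl group on a urea-bearing core

The source may report more compounds than this note shows. Statements on the series, on what has been measured and on what is new or still open speak of the compounds shown alone.

Measured so far:
compound 1 `Cc1cc(F)cc(Nc2cc(NC(=O)Nc3c(Cl)cccc3Cl)ncn2)c1`: 49.1%
compound 2 `COc1cc(NC(=O)Nc2cc(Nc3cccc(C(C)(C)C)c3)ncn2)cc(OC)c1`: 48.7%

In a functional assay on HCC827 cells (Homo sapiens) for inhibition, read by MTT assay, with a stated time of 48 h, tested at 10 uM (on this read-out higher numbers stand for more inhibition at the one concentration tested (going by the name of the read-out) and lower numbers for less inhibition), compound 1 gives 49.1%. In this assay compound 2 gives 48.7%, a number that sits within the usual scatter of the value for compound 1, so the two cannot be told apart. Compound 3 `COc1cc(NC(=O)Nc2cc(Nc3ccc(OC)c(C)c3)ncn2)cc(OC)c1` has not yet been measured. It differs from compound 2 in one place: 4-methoxy-3-methylphenyl in place of 3-(tert-butyl)phenyl on a nitrogen on an aromatic ring. Within the data shown here, no measured pair shows what such a change does here. The step of a number 3.7 percentage points lower from compound 2 to compound 3 (within the scatter) is expected to stay within the scatter, in no particular direction. Compound 3 is therefore estimated at 45%, between 20% and 72%.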

Compound 3, a percentage reported as inhibition, at one concentration (the size of the read-out at that concentration, not a potency): 48.3%
Compound 3: middle estimate off by 3.3 percentage points, on the low side; the measured number falls inside the stated range.
By their numbers in this assay, from the lowest: compounds 3, 2 and 1 (each within the scatter of the next).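

In this assay, putting 4-methoxy-3-methylphenyl in place of 3-(tert-butyl)phenyl on a nitrogen on an aromatic ring gives a number 0.4 percentage points lower from compound 2 to compound 3 (within the scatter). Among these compounds, this is the first measured step at this position, and it shows that a group of carbon only and a group that carries an oxygen cannot be told apart here. Nothing measured offers a reason for this result. Still open, going by these compounds, is whether an amine or a carboxylic acid on that phenyl ring would give a step beyond the scatter.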